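The source may hold more compounds than are shown below. What is called first, only, known or untested is meant among the compounds shown, and "the series" means these compounds.

Measured in a functional assay on PANC-1 cells (Homo sapiens) for inhibition, read by MTT assay, with a stated time of 24 h; a lower number here means a stronger inhibitor, a higher number a weaker inhibitor:
- compound 1 `CC1(C)[C@H]2CC[C@]1(C)N(Cc1cn(-c3cccc(C#N)c3)nn1)C(=O)C2`: 260 nM
- compound 2 `CC1(C)[C@H]2CC[C@]1(C)N(Cc1cn(-c3cccc(Br)c3)nn1)C(=O)C2`: 90 nM
- compound 3 `COc1cccc(-n2cc(CN3C(=O)C[C@@H]4CC[C@@]3(C)C4(C)C)nn2)c1`: 860 nM

Compound 3 has the highest number of the three and so is the weakest inhibitor among them. It lies behind the other two by a 3.3-fold higher number from compound 1 to compound 3 (0.52 log units; beyond the scatter) and a 9.6-fold higher number from compound 2 to compound 3 (0.98 log units; beyond the scatter). The next compound, compound 4 `COc1ccc(-n2cc(CN3C(=O)C[C@@H]4CC[C@@]3(C)C4(C)C)nn2)cc1`, carries 4-methoxyphenyl in place of 3-methoxyphenyl on an aromatic nitrogen. The two have the same atoms, joined differently.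

Going by the values given here, no measured step moves a group in this way. The nearest guide is the set of exchanges on an aromatic carbon, which also include a 2.9-fold lower number from compound 1 to compound 2 (0.46 log units; beyond the scatter). These steps are all modest, and they give only a rough ceiling on size, not a direction. A step no larger than these is expected in this assay, possibly within the scatter. There is a slight lean towards a lower number because compound 3 sits at 860 nM, the top of the three. The expected change is a 1.6-fold lower number from compound 3 to compound 4 (0.19 log units; within the scatter). For compound 4 the estimate is 550 nM, with an expected range of 150 nM to 2000 nM.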

Compound 4, half-maximal inhibitory concentration: 330 nM
Beside the measured number, compound 4's estimate is 1.7-fold (0.22 log units) above it; low and high end bracket the measured number.
By their numbers in this assay, from the lowest: compound 2; then compounds 1 and 4 (each within the scatter of the next); then compound 3.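

In this assay, moving the methoxy group alone, with 4-methoxyphenyl in place of 3-methoxyphenyl on the aromatic nitrogen, shifts the result (a 2.6-fold lower number from compound 3 to compound 4 (0.42 log units; beyond the scatter)). This shows that the placement of a substituent on this phenyl ring matters, and not only its identity, as the earlier exchanges had shown. The change also brings methoxy level with the 3-cyanophenyl compound (a 1.3-fold higher number from compound 1 to compound 4 (0.10 log units; within the scatter)), but the 3-bromophenyl compound keeps its lead (a 3.7-fold higher number from compound 2 to compound 4 (0.56 log units; beyond the scatter)), and no measurement offered here accounts for the effect of the move.

The compounds shown leave open whether bromo and cyano respond to the same move, as 4-bromophenyl and 4-cyanophenyl would show. They also leave open how a phenyl ring bearing an amine or a carboxylic acid would behave at this position.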